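Tetrahydroquinoline for Methylpiperidine: Expected Vero Tolerability

A few compounds are considered here, and "the series" means these few. Any claim that something is new, unique, unknown or untested is made for them only; others in the source may bear on it.

Compound 1 `COc1cccc(CN2C(=O)CN(C(=O)c3cc4cc(OC)ccc4[nH]3)C[C@@H]2COCc2ccccc2)c1` in an ADME assay on Vero cells (Chlorocebus sabaeus) for cytotoxicity, with a stated time of 7 days (a higher number here means that more compound is tolerated, a lower number that less compound is tolerated), is reported only as the limit > 10000 nM.
Compound 2 `COc1ccc2[nH]c(C(=O)N3CC(=O)N(Cc4ccccc4)[C@@H](CN4CCC(C)CC4)C3)cc2c1` in this assay is reported only as the limit > 30000 nM.
Compound 3 `COc1ccc2[nH]c(C(=O)N3CC(=O)N(Cc4ccoc4)[C@@H](Cc4ccccc4)C3)cc2c1` in this assay is reported only as the limit > 10000 nM.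

None of the three compounds gives a number in this assay; every value is a limit. Compound 2 therefore cannot be placed in any order against the others: two of the values sit at the limit of > 10000 nM in this assay, at which 2 of the 3 values shown sit, and compound 2 alone is reported at the limit of > 30000 nM in this assay, at which 1 of the 3 values shown sits. No pair of these compounds differs in one place only, so no measured step exists from which a direction could be read.

Compound 4 `COc1ccc2[nH]c(C(=O)N3CC(=O)N(Cc4ccccc4)[C@@H](CN4CCCc5ccccc54)C3)cc2c1` is the unmeasured analogue of compound 2. The change is 1,2,3,4-tetrahydroquinolin-1-yl in place of 4-methylpiperidin-1-yl on a saturated chain carbon bound to a saturated ring carbon. With compound 2 giving only a limit in this assay, and the other two compounds likewise giving only limits, there is no measured effect of any group on the read-out to build on, and the expected step of a number no higher from compound 2 to compound 4 (the limit leaves the size open) is one of no change beyond the scatter. Compound 4 is accordingly expected to give 30000 nM in this assay, within 10000 nM to 100000 nM, most likely again reported as a limit rather than a number.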

Compound 4, half-maximal cytotoxic concentration: > 100000 nM
Compound 4: no number, only a limit; the forecaster's own chance of this, stated with the estimate: 80%; middle value at least 3.3-fold (0.52 log units) away from the limit.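

Compound 2 and compound 4 are both reported only as limits, so the step between them cannot be read. The limit of compound 4 stands alone among the values shown: the limit of > 100000 nM in this assay, at which 1 of the 4 values shown sits. The compounds shown leave open whether 1,2,3,4-tetrahydroquinolin-1-yl in place of 4-methylpiperidin-1-yl changes the tolerated concentration in this assay at all.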